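Shorter Arm, Chlorine for Bromine, Same Expected Outcome

The compounds below may be only part of what the source reports. "The series", "measured", "known", "first", "only" and "open" are said of these compounds alone.

Compound 1 `O=S(=O)(NCCCNCc1cccc2ccccc12)c1cc(C(F)(F)F)cc(C(F)(F)F)c1` and compound 2 `O=S(=O)(NCCCCNCc1ccc(Br)cc1)c1cc(C(F)(F)F)cc(C(F)(F)F)c1` share a common core. In a toxicity assay on MCF-10A cells (Homo sapiens) for inhibition, read by MTT assay, with a stated time of 72 h (a lower number here means a stronger inhibitor of growth, a higher number a weaker inhibitor of growth), compound 1 gives 3200 nM. In this assay compound 2 gives 3200 nM, which places it level with compound 1 within the usual scatter. Compound 3 `O=S(=O)(NCCCNCc1cccc(Cl)c1)c1cc(C(F)(F)F)cc(C(F)(F)F)c1` differs from compound 2 by (3-chlorobenzyl)amino in place of ((4-bromobenzyl)amino)methyl on a saturated chain carbon, three bonds along the chain from a sulfonamide nitrogen. Going by the values given here, since no measured pair separates such a change, and since compounds 1 and 2 agree despite their differing arms, the expected step of no change at the digits printed from compound 2 to compound 3 (within the scatter) is none beyond the scatter. Compound 3 is therefore estimated at 3200 nM, between 1400 nM and 7500 nM.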

Compound 3, concentration for 50% growth inhibition: 7000 nM
Estimate against measurement, compound 3: 2.2-fold (0.34 log units) below, within the range that was stated.
By their numbers in this assay, from the lowest: compounds 1 and 2 (each within the scatter of the next); then compound 3.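

In this assay, (3-chlorobenzyl)amino in place of ((4-bromobenzyl)amino)methyl on a saturated chain carbon, three bonds along the chain from a sulfonamide nitrogen, gives a 2.2-fold higher number from compound 2 to compound 3 (0.34 log units; beyond the scatter) and so shows a modest change at this position beyond the scatter. The swap of naphthalen-1-yl for 3-chlorophenyl gives a 2.2-fold higher number from compound 1 to compound 3 (0.34 log units; beyond the scatter) in the same direction, towards weaker inhibition of growth. Nothing measured here explains this shift. Going by these compounds, whether a longer chain carrying 3-chlorobenzyl, or a nitrile in place of the chlorine, would restore the level of compound 2 remains open.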